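The source may report more compounds than this note shows. Statements on the series, on what has been measured and on what is new or still open speak of the compounds shown alone.

Measured so far:
Compound 1 `Cc1ccc2nc(Nc3nc(Nc4ccc(S(N)(=O)=O)cc4)ncc3C)sc2c1` gives > 50000 nM in a functional assay on MCF7 cells (Homo sapiens) for antiproliferative activity, read by MTT assay, with a stated time of 48 h; on this read-out lower numbers stand for stronger inhibition and higher numbers for weaker inhibition; that value is a limit of the assay, not a number.
Compound 2 `Cc1cnc(Nc2ccc(S(N)(=O)=O)cc2)nc1Nc1nc2ccc(Cl)cc2s1` gives 8430 nM in this assay.

Going by the values given here, compound 2 thus holds the only real number in this assay, the other entry being a limit. Among the compounds with values here, the single measured step, an at least 5.9-fold lower number from compound 1 to compound 2 (0.77 log units; beyond the scatter), starts from that limit (the limit of > 50000 nM in this assay, at which 1 of the 2 values shown sits), so its true size is known only as a lower bound. Compound 3 `COc1ccc2nc(Nc3nc(Nc4ccc(S(N)(=O)=O)cc4)ncc3C)sc2c1` differs from compound 2 by methoxy in place of chloro on an aromatic carbon, at the same position where compound 1 and compound 2 differ. Within the data shown here, no measured step swaps chloro for methoxy, so the step from compound 2 to compound 3 cannot be read directly from anything measured; the only hint is that a change at this position, from methyl to chloro, moved the number at least modestly, and methoxy is neither of those groups. Compound 3 is therefore expected to give a higher number than compound 2, with some chance of reaching the limit again, and is estimated at 25000 nM (between 6000 nM and 80000 nM), a step of a 3.0-fold higher number from compound 2 to compound 3 (0.47 log units; beyond the scatter).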

Compound 3, half-maximal inhibitory concentration: > 50000 nM
Compound 3: a limit, no number; the forecaster's own chance of this, stated with the estimate: 35%; middle value at least 2.0-fold (0.30 log units) away from the limit.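

Among the three groups shown on this aromatic carbon, only the chloro of compound 2 gives a real number in this assay, 8430 nM. The methyl of compound 1 and the methoxy of compound 3 both leave the compound at a limit. Replacing chloro with methoxy gives an at least 5.9-fold higher number from compound 2 to compound 3 (0.77 log units; beyond the scatter), so a second change at this position also moves the result beyond the scatter, and the better result seen with chloro does not carry over to methoxy. The readable steps are lower bounds, and the step between compound 1 and compound 3 cannot be read, because both of those entries are limits: the limit of > 50000 nM in this assay, at which 2 of the 3 values shown sit.

With only one real number, the compounds shown give no trend across groups at this position, and they cannot separate the effect of the methoxy oxygen from that of its added carbon. As far as these compounds go, whether a fluoro, a bromo, an amine or a carboxylic acid at this position would give a number like that of compound 2, or a lower one, remains open.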